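The source may report more compounds than this note shows. Statements on the series, on what has been measured and on what is new or still open speak of the compounds shown alone.

Working notes on the series sharing the core of compound 1 `O=C1C(Nc2ccccc2)=CC(=O)c2c1nc1n2[C@H]2OC[C@@H](O)[C@H]2OC1`.

In a functional assay on HeLa cells (Homo sapiens) for inhibition, read by sulforhodamine B assay (a higher number here means a weaker inhibitor, a lower number a stronger inhibitor), compound 1 gives only a limit, > 8000 nM, not a number. Compound 2 `Cc1ccc(NC2=CC(=O)c3nc4n(c3C2=O)[C@H]2OC[C@@H](O)[C@H]2OC4)cc1`, carrying 4-methylphenyl on the amine nitrogen, gives 3860 nM in this assay. Compound 3 `COc1cccc(NC2=CC(=O)c3nc4n(c3C2=O)[C@H]2OC[C@@H](O)[C@H]2OC4)c1`, carrying 3-methoxyphenyl there, gives 4280 nM in this assay. Among the compounds with values here, the one measured step, a 1.1-fold higher number from compound 2 to compound 3 (0.04 log units; within the scatter), is within the scatter, so the two substituted anilines show no difference between them. Compound 1 stands apart on the numbers only in that (the limit of > 8000 nM in this assay, at which 1 of the 3 values shown sits), a limit, is all that this assay returned for it.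

Compound 4 `O=C1C(Nc2cccc(Cl)c2)=CC(=O)c2c1nc1n2[C@H]2OC[C@@H](O)[C@H]2OC1` differs from compound 1 by chloro in place of hydrogen on an aromatic carbon. Within the data shown here, no measured step covers exactly this change; the nearest bearings are the values of compound 2 and compound 3, both of which carry a substituted phenyl and both of which fall in the measurable range. On that basis compound 4 is expected to land near compound 2 and compound 3, an expected step of an at least 2.2-fold lower number from compound 1 to compound 4 (0.35 log units; beyond the scatter) from the limit. The estimate for compound 4 in this assay is 3500 nM, with a range from 1500 nM to 8000 nM.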

Compound 4, half-maximal inhibitory concentration: 7970 nM
Estimate against measurement, compound 4: 2.3-fold (0.36 log units) below; the measured number falls inside the stated range.
By their numbers in this assay, from the lowest: compounds 2, 3 and 4 (each within the scatter of the next, the first and the last beyond it). At a limit, above all of these: compound 1.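

In this assay compound 4, with chloro on an aromatic carbon meta to a large group, gives a number, 7970 nM, where the unsubstituted phenyl of compound 1 gave none. Chloro in place of hydrogen on an aromatic carbon gives a number no higher from compound 1 to compound 4 (the limit leaves the size open) in this assay. The size of the change from hydrogen to chloro cannot be read, because compound 1 has only a limit, not a number: the limit of > 8000 nM in this assay, at which 1 of the 4 values shown sits.

Compound 3, with 3-methoxyphenyl, gives 4280 nM and compound 4, with 3-chlorophenyl, gives 7970 nM, values within the scatter of each other, so these two groups are not told apart in this assay.

Going by these compounds, how an amine or a carboxylic acid would read at this position remains open. So does whether chloro on another carbon of the same ring would give a number like that of compound 4.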